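The compounds below may be only part of what the source reports. "The series", "measured", "known", "first", "only" and "open" are said of these compounds alone.

Of the compounds shown here, three built on a shared core have been measured in a functional assay on isolated protein for inhibition of Glucose-dependent insulinotropic receptor (Rattus norvegicus), read by HTRF and cAMP accumulation; on this read-out lower numbers stand for smaller maximal responses and higher numbers for larger maximal responses. Compound 1 `Cc1nc(S(C)(=O)=O)ccc1Oc1ncnc(OC2CCN(C(=O)OC(C)(C)C(F)(F)F)CC2)c1F` gives 79%, compound 2 `Cc1nc(S(C)(=O)=O)ccc1Oc1ncnc(OC2CCN(C(=O)OC3(C(F)(F)F)COC3)CC2)c1F` gives 84%, and compound 3 `Cc1nc(S(C)(=O)=O)ccc1Oc1ncnc(OC2CCN(C(=S)OC(C)C)CC2)c1F` gives 47%. Compound 3 stands lowest of the three: the step of a number 32 percentage points lower from compound 1 to compound 3 (beyond the scatter) and the step of a number 37 percentage points lower from compound 2 to compound 3 (beyond the scatter) both lie beyond the scatter, whereas the step of a number 5 percentage points higher from compound 1 to compound 2 (within the scatter) does not.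

Compound 4 `Cc1nc(S(C)(=O)=O)ccc1Oc1ncnc(OC2CCN(C(=O)c3noc(C(C)(C)F)n3)CC2)c1F` is now to be measured in this assay. It differs from compound 3 in one place: a group of 11 heavy atoms (6 carbon, 2 nitrogen, 2 oxygen, 1 fluorine; one five-membered aromatic ring with 3 hetero atoms) in place of a group of 6 heavy atoms (4 carbon, 1 oxygen, 1 sulfur; no ring), on an amine nitrogen in a ring. The two measured steps that bear on this change run the other way: going from the larger groups of compound 1 and compound 2 to the group of 6 heavy atoms on an amine nitrogen in a ring cost a large part of the maximal response each time. Compound 4 brings back a group of 11 heavy atoms on that amine nitrogen in a ring, so a large upward step is expected, a number 28 percentage points higher from compound 3 to compound 4 (beyond the scatter). Compound 4 is therefore estimated at 75%, within a range from 55% to 95%.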

Compound 4, largest response reached (reported as efficacy), in percent of the reference or control that the assay uses: 74%
The estimate for compound 4 lay 1 percentage points above the measured number; the range from low to high includes it.
By their numbers in this assay, from the lowest: compound 3; then compounds 4, 1 and 2 (each within the scatter of the next).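

In this assay, the step of a number 27 percentage points higher from compound 3 to compound 4 (beyond the scatter) shows that a large response at the amine nitrogen in a ring does not depend on the groups of compound 1 and compound 2, since a group with a five-membered aromatic ring with 3 hetero atoms also gives it. On the carbonyl carbon, the steps of a number 10 percentage points lower from compound 2 to compound 4 (within the scatter) and a number 5 percentage points lower from compound 1 to compound 4 (within the scatter) show that this aromatic ring can take the place of either earlier group without a change that can be told from the scatter. Nothing available explains why these groups give such similar responses.

Going by these compounds, compound 3 differs from the others in both its sulfur and its isopropyl group, so it remains open which of the two goes with its lower response. On these data alone, it also remains open whether a pyridine ring or a simple isopropyl group on the carbonyl carbon would keep the response.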